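Cytotoxicity limits across a small quinolone ester set

A few compounds are considered here, and "the series" means these few. Any claim that something is new, unique, unknown or untested is made for them only; others in the source may bear on it.

Measured compounds:
compound 1 `CCOC(=O)c1c(-c2cc(F)cc(OC)c2)[nH]c2cc(OC)ccc2c1=O` — > 21500 nM
compound 2 `CCOC(=O)c1c(-c2cccc(Br)c2)[nH]c2cc(OC)ccc2c1=O` — > 21500 nM
compound 3 `CCOC(=O)c1c(-c2cccc(Br)c2)[nH]c2cc(OC)c(F)cc2c1=O` — > 21500 nM

In an ADME assay on Raji cells (Homo sapiens) for cytotoxicity, read by luminescence, with a stated time of 72 h (a lower number here means that less compound is needed, a higher number that more compound is needed for the effect), compound 1 reaches only a limit, > 21500 nM. Compound 2 likewise gives only a limit in this assay, > 21500 nM. Compound 3 also sits at a limit in this assay, > 21500 nM. All three share (the limit of > 21500 nM in this assay, at which 3 of the 3 values shown sit), so the steps between them cannot be sized: a step that the two limits leave unreadable from compound 2 to compound 1 and a step that the two limits leave unreadable from compound 2 to compound 3.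

The cores of compound 2 and compound 3 differ by fluoro in place of hydrogen on an aromatic carbon. The unmeasured compound 4 `CCOC(=O)c1c(-c2cc(F)cc(OC)c2)[nH]c2cc(OC)c(F)cc2c1=O` relates to compound 3 through (3-fluoro-5-methoxyphenyl in place of 3-bromophenyl on an aromatic carbon), the same change that separates compound 2 from compound 1, (3-fluoro-5-methoxyphenyl in place of 3-bromophenyl on an aromatic carbon); the surroundings of the place are the same in both cases.

Because the limit of > 21500 nM in this assay, at which 3 of the 3 values shown sit, holds for compound 1, compound 2 and compound 3 alike, compound 4 is expected to stay at that limit too. For compound 4 in this assay the estimate is 30000 nM, between 15000 nM and 120000 nM, meaning an expected step that the limit leaves unreadable from compound 3 to compound 4.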

Compound 4, half-maximal effective concentration in the Raji assay: > 21500 nM
Compound 4 gave a limit, no number; the forecaster's own chance of this, stated with the estimate: 85%; the middle value does not contradict the limit.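

In the Raji assay compound 4 gives only a limit, > 21500 nM. The steps to it from compound 1 and compound 3 cannot be read, and the whole set stays at one limit: the limit of > 21500 nM in the Raji assay, at which 4 of the 4 values shown sit. The compounds shown leave open whether any change to the shared core or the aryl group would give a measurable value in the Raji assay. In a physicochemical assay for solubility, at pH 7.4 (a higher number here means a more soluble compound, a lower number a less soluble compound), compound 3 gives 7300 nM and compound 4 gives 7500 nM (a 1.0-fold higher number from compound 3 to compound 4 (0.01 log units; within the scatter)).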